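The compounds below may be only part of what the source reports. "The series", "measured", "known", "first", "only" and "open" are said of these compounds alone.

Compound 1 `O=S(=O)(c1cccc(-c2ccc3nccc(-c4ccncc4)c3n2)c1)N1CCC(O)CC1`: 10000 nM
Compound 2 `NS(=O)(=O)c1cccc(-c2ccc3nccc(N4CCN(Cc5ccccc5)CC4)c3n2)c1`: < 5000 nM

For the measured compounds named here, in a physicochemical assay for solubility, read by HPLC, using the shake flask method, measured as kinetic solubility, with a stated time of 20 h, at pH 6.5, tested at 200 uM (on this read-out lower numbers stand for lower solubility and higher numbers for higher solubility), compound 1 gives 10000 nM, the only actual number available so far. Compound 2 is reported as < 5000 nM, which is a limit of the assay and not a number.

The step followed here leads from compound 1 to compound 3 `Nc1cccc(-c2ccc3nccc(-c4ccncc4)c3n2)c1`, which has not yet been measured. On an aromatic carbon of a six-membered aromatic ring of carbon only, meta to a large group, amino stands in place of (4-hydroxypiperidin-1-yl)sulfonyl: amino in place of (4-hydroxypiperidin-1-yl)sulfonyl on an aromatic carbon.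

Going by the values given here, no two measured compounds differ in just one place, so the data do not show what size of change such a swap brings. The expectation therefore rests on compound 1 alone, at 10000 nM, and no direction is favoured. The expected change is no change at the digits printed from compound 1 to compound 3 (within the scatter), an estimate that stays within the usual scatter of repeated measurements in this assay. For compound 3 the estimated solubility is 10000 nM, with an expected range of 3000 nM to 35000 nM.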

Compound 3, solubility: < 5000 nM
Compound 3: a limit, no number; the forecaster's own chance of this, stated with the estimate: 30%; middle value at least 2.0-fold (0.30 log units) away from the limit.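

For the compounds shown here, at this place, on an aromatic carbon of a six-membered aromatic ring of carbon only, meta to a large group, the first comparison in one place is now available: with amino in place of (4-hydroxypiperidin-1-yl)sulfonyl, this assay gives an at least 2.0-fold lower number from compound 1 to compound 3 (0.30 log units; that floor lies within the scatter). Compound 3 is reported as < 5000 nM, which is a limit of the assay and not a number. The step therefore gives only a smallest possible size, not a true size, and on its own it cannot separate a real drop from ordinary scatter, because compound 3 sits at the assay's limit: the limit of < 5000 nM in this assay, at which 2 of the 3 values shown sit.

On these data alone, what remains open is how other groups on this same aromatic carbon would read, such as a carboxylic acid or a short chain ending in an amine, and whether any of them would give an actual number instead of a limit. Compound 2 differs from compound 1 and from compound 3 in more than one place, so it adds no further comparison of this change.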